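The compounds below may be only part of what the source reports. "The series", "measured", "known", "first", "only" and "open" are said of these compounds alone.

Values measured in a functional assay on A549 cells (Homo sapiens) for inhibition, read by MTT assay, with a stated time of 24 h; a lower number here means a stronger inhibitor, a higher number a weaker inhibitor:
- compound 1 `CC1(C)[C@H]2CC[C@]1(C)N(Cc1cn(-c3ccc(C#N)cc3)nn1)C(=O)C2`: 140 nM
- compound 2 `CC1(C)[C@H]2CC[C@]1(C)N(Cc1cn(-c3cccc(C#N)c3)nn1)C(=O)C2`: 440 nM
- compound 3 `COc1ccccc1-n1cc(CN2C(=O)C[C@@H]3CC[C@@]2(C)C3(C)C)nn1`: 350 nM

Compound 3 is level with compound 2 within the scatter, as a 1.3-fold lower number from compound 2 to compound 3 (0.10 log units; within the scatter) shows. Compound 1 carries the lowest number of the three, with a 2.5-fold higher number from compound 1 to compound 3 (0.40 log units; beyond the scatter) and a 3.1-fold higher number from compound 1 to compound 2 (0.50 log units; beyond the scatter), both modest but beyond the scatter.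

Compound 4 `CC1(C)[C@H]2CC[C@]1(C)N(Cc1cn(-c3ccccc3O)nn1)C(=O)C2` departs from compound 3 by one change: hydrogen in place of methyl on an oxygen on an aromatic ring. This places hydrogen in place of methyl on an oxygen on an aromatic ring, turning 2-methoxyphenyl into 2-hydroxyphenyl.

Within the data shown here, no measured pair makes this exact change, so the evidence is indirect. The three steps above all exchange the whole group on the aromatic nitrogen, and none is more than modest. A smaller edit to that group is therefore expected to move this assay little, and the direction is open. The estimate means a 1.2-fold lower number from compound 3 to compound 4 (0.07 log units; within the scatter), so no step beyond the scatter is expected. For compound 4 the estimated value is 300 nM, with an expected range from 110 nM to 800 nM.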

Compound 4, half-maximal inhibitory concentration: 230 nM
Estimate against measurement, compound 4: 1.3-fold (0.12 log units) above; the measured number falls inside the stated range.
By their numbers in this assay, from the lowest: compounds 1, 4, 3 and 2 (each within the scatter of the next, the first and the last beyond it).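

Among these compounds, the change from methoxy to hydroxy is the first edit here that alters the group on the aromatic nitrogen without replacing it, and in this assay this small edit stays within the scatter (a 1.5-fold lower number from compound 3 to compound 4 (0.18 log units; within the scatter)), so the methyl on that oxygen can go without a step that can be told from repeat noise. The 2-hydroxyphenyl group also lies within the scatter of both cyanophenyl groups (a 1.9-fold lower number from compound 2 to compound 4 (0.28 log units; within the scatter); a 1.6-fold higher number from compound 1 to compound 4 (0.22 log units; within the scatter)), even though those two are separated beyond it (a 3.1-fold higher number from compound 1 to compound 2 (0.50 log units; beyond the scatter)). Nothing given here offers an explanation for these numbers.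

The compounds shown leave open how this assay would respond to ethoxy, an amine or a carboxylic acid in place of the hydroxy on the phenyl ring. They also leave open whether the same exchange of methoxy for hydroxy would stay as small on another phenyl group.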